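Swapping the Fluorine Around a Benzylamine

The source may report more compounds than this note shows. Statements on the series, on what has been measured and on what is new or still open speak of the compounds shown alone.

Three compounds have been measured so far in an ADME assay on Vero cells (Chlorocebus sabaeus) for cytotoxicity, read by MTT assay, with a stated time of 48 h; on this read-out higher numbers stand for weaker inhibition and lower numbers for stronger inhibition:
Compound 1 `O=C1CN(c2nc(=O)c3cc(C(F)(F)F)cc([N+](=O)[O-])c3o2)CCN1CC1CCCCC1` gives 25.4 ug/mL.
Compound 2 `O=c1cc(NCc2cccc(F)c2)sc2c([N+](=O)[O-])cc(C(F)(F)F)cc12` gives only a limit of the assay, > 64 ug/mL.
Compound 3 `O=c1nc(NCc2ccccc2)oc2c([N+](=O)[O-])cc(C(F)(F)F)cc12` gives 25.4 ug/mL.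

Compound 1 and compound 3 show the same value in this assay, so no order can be drawn between them. Compound 2 stands apart from both: its result is not a number but a limit, and it is the one that sits at the limit of > 64 ug/mL in this assay, at which 1 of the 3 values shown sits. Nothing more can be said about how far beyond that limit it lies.

Compound 4 `O=c1cc(NCc2ccc(F)cc2)sc2c([N+](=O)[O-])cc(C(F)(F)F)cc12` has not yet been measured. It differs from compound 2 in a single place: 4-fluorophenyl in place of 3-fluorophenyl on a saturated chain carbon bound to a nitrogen on an aromatic ring. The 3-fluorobenzyl group of compound 2 gives way to a 4-fluorobenzyl group in compound 4, while everything else is kept.

Among the compounds with values here, no measured pair shows what this kind of change does in this assay. Compound 2 gives only a limit, > 64 ug/mL. Within the data shown here, with no step of this type on record, the expectation for the move from compound 2 to compound 4 is a step within the usual scatter, in no particular direction. Compound 4 is therefore estimated at 70 ug/mL, with an expected range from 32 ug/mL to 150 ug/mL. The expected step is a step that the limit leaves unreadable from compound 2 to compound 4, and the assay is quite likely to report only a limit again.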

Compound 4, half-maximal inhibitory concentration: > 64 ug/mL
Compound 4 was reported as a limit; the forecaster's own chance of this, stated with the estimate: 70%; the middle value does not contradict the limit.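

Compound 2 and compound 4 are both reported only as limits in this assay, so no step can be read between them: the limit of > 64 ug/mL in this assay, at which 2 of the 4 values shown sit.

The compounds shown leave open how compound 2 and compound 4 truly compare, and whether 4-fluorophenyl in place of 3-fluorophenyl changes the result at all.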